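Ring closure on the amide nitrogen of a quinolinone antagonist

A few compounds are considered here, and "the series" means these few. Any claim that something is new, unique, unknown or untested is made for them only; others in the source may bear on it.

Measured so far:
compound 2, `CC[C@H](NC(=O)COc1ccc2[nH]c(=O)c(-c3nccs3)c(CCc3ccccc3)c2c1)c1ccccc1`: 0.4 nM
compound 1, `Cc1cc(-c2c(CCc3ccccc3)c3cc(OCC(=O)NC(C)(C)c4ccccc4)ccc3[nH]c2=O)on1`: "not determined" (no result reported)

Compound 1 carries a tert-butyl-type group on its amide nitrogen, but in a functional assay on HMC-1 cells for antagonist activity at adenosine receptor A2b (Homo sapiens), read by ELISA, with a stated time of 6 h (a higher number here means a weaker inhibitor, a lower number a stronger inhibitor), compound 1 gives "not determined" (no result reported), so no number exists for it. Among the compounds with values here, compound 2 is therefore the only compound with a value: in this assay compound 2 gives 0.4 nM, which places it as the sole reference point in this set.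

Compound 3, `O=C(COc1ccc2[nH]c(=O)c(-c3nccs3)c(CCc3ccccc3)c2c1)NC1(c2ccccc2)CC1`, differs from compound 2 in one place: 1-phenylcyclopropyl in place of 1-phenylpropyl on an amide-type nitrogen. The groups that leave and enter hold the same count of heavy atoms, and the stereocentre disappears with the ring closure. Within the data shown here, no step between measured compounds is available to guide the size of this change, so the expectation rests on the single value of compound 2 alone.

The expected step from compound 2 to compound 3 in this assay is a 2.0-fold higher number from compound 2 to compound 3 (0.30 log units; within the scatter), a change not clearly beyond the scatter of repeated measurements. Compound 3 is estimated at 0.8 nM, with a range from 0.2 nM to 4 nM.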

Compound 3, inhibition constant: 1 nM
Compound 3: middle estimate off by 1.3-fold (0.10 log units), on the low side; the range from low to high includes it.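

Closing the 1-phenylpropyl group on the amide-type nitrogen into 1-phenylcyclopropyl gives a 2.5-fold higher number from compound 2 to compound 3 (0.40 log units; beyond the scatter) in this assay, the first step measured at this position. The defined stereocentre of compound 2 is gone, and compound 3 still reads 1 nM in this assay, so the ring closure costs only a modest step and the value stays low. Nothing measured here explains the direction or size of this step.

With compound 1 at "not determined" (no result reported) in this assay, the shown compounds offer no second value for a group on this nitrogen. They leave open whether a larger ring, as in 1-phenylcyclobutyl, or a pyridyl ring in place of the phenyl on the cyclopropane would hold the value of compound 3.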